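The compounds below may be only part of what the source reports. "The series", "measured", "known", "first", "only" and "open" are said of these compounds alone.

Measured so far in an ADME assay on S9 fraction from liver (Rattus norvegicus) for metabolic stability, read by LC-MS, using NADPH, with a stated time of 30 min; on this read-out lower numbers stand for a less stable compound and higher numbers for a more stable compound:

compound 1, `CCCCCCCCc1ccc(OCC(=O)Cn2nnc(-c3ccc(C(=O)O)cc3)n2)cc1`, gives < 5%
compound 2, `CCCCCCCCc1ccc(OCC(=O)Cn2nnnc2-c2ccccc2)cc1`, gives 36%

The result for compound 1 is a limit of the assay and not a number; it stands at the limit of < 5% in this assay, at which 1 of the 2 values shown sits. For the measured compounds named here, compound 2 therefore holds the only number in this assay, and the one other value shown is a limit. Going by the values given here, nothing is known here about any step between two measured compounds that differ in a single place, so no measured step guides what follows.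

Compound 3, `CCCCCCCCc1ccc(OCC(=O)Cn2nnnc2Cc2ccccc2)cc1`, has not yet been measured. It differs from compound 2 in one place: benzyl in place of phenyl on an aromatic carbon. Among the compounds with values here, since no measured step tells what a benzyl in place of a phenyl does in this assay, the expectation rests on compound 2 alone. Compound 3 is expected to come out somewhat lower than compound 2, with a step of a number 11 percentage points lower from compound 2 to compound 3 (beyond the scatter) that may or may not pass beyond the usual scatter. Compound 3 is estimated at 25%, with a range from 8% to 45%.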

Compound 3, percent of the compound remaining: 26%
For compound 3 the middle estimate is 1 percentage points below the measured one; measured number inside the range.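

Putting benzyl in place of phenyl on an aromatic carbon of the five-membered ring gives a number 10 percentage points lower from compound 2 to compound 3 (within the scatter) in this assay. For the compounds shown here, this is the first single-place comparison, and it shows that, on this read-out, the position takes a benzyl as well as a phenyl with no change that can be told from the usual scatter, so compound 2 and compound 3 stand level here and the added carbon makes no measurable difference to the percent of compound remaining. Nothing measured here gives a cause for this result, and the only recorded observation concerns a limit of the assay rather than this change.

What the compounds shown leave open is whether this level holds for other groups at the same position, such as an amine, a carboxylic acid on the benzyl ring or a longer chain ending in phenyl, and whether changes elsewhere on the shared core, such as a shorter chain in place of the long one, would matter more. Compound 1 differs from compound 2 and from compound 3 in more than one place, so it cannot settle either question.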